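Methoxy on the anilide phenyl: from compound 3 to compound 4

A few compounds are considered here, and "the series" means these few. Any claim that something is new, unique, unknown or untested is made for them only; others in the source may bear on it.

Compound 1 `O=C(/C=C/c1coc2cc(O)ccc2c1=O)NCc1ccc(F)cc1` gives > 100000 nM in a functional assay on HeLa cells (Homo sapiens) for inhibition, read by MTT assay, with a stated time of 48 h (a lower number here means a stronger inhibitor, a higher number a weaker inhibitor), which is a limit of the assay and not a number.
Compound 2 `Cc1ccc(CNC(=O)/C=C/c2coc3cc(O)ccc3c2=O)cc1` gives > 100000 nM, again a limit and not a number.
Compound 3 `O=C(/C=C/c1coc2cc(O)ccc2c1=O)Nc1ccccc1` gives 9700 nM.

Within the data shown here, compound 3 thus carries the only actual number among the three; the other two sit at the limit of > 100000 nM in this assay, at which 2 of the 3 values shown sit. The measured steps to compound 3 are an at least 10-fold lower number from compound 1 to compound 3 (1.01 log units; beyond the scatter) and an at least 10-fold lower number from compound 2 to compound 3 (1.01 log units; beyond the scatter), both large, and both concern the exchange of a benzyl-type group for a phenyl on the amide-type nitrogen. The step that the two limits leave unreadable from compound 1 to compound 2 is not readable from the two limits.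

Compound 4 `COc1ccc(NC(=O)/C=C/c2coc3cc(O)ccc3c2=O)cc1` differs from compound 3 by methoxy in place of hydrogen on an aromatic carbon. Among the measured compounds shown here, no measured step here bears directly on adding a methoxy to the phenyl; the large steps describe a different change. With nothing to point either way, no step beyond the scatter is expected. The estimated step is a 1.2-fold lower number from compound 3 to compound 4 (0.08 log units; within the scatter). Compound 4 is therefore expected to give about 8000 nM, within a range of 2500 nM to 30000 nM.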

Compound 4, half-maximal inhibitory concentration: > 100000 nM
Compound 4: a limit, no number (the forecaster's own chance of this, stated with the estimate: 8%); middle value at least 12-fold (1.09 log units) away from the limit.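

The earlier steps shown here concerned only the group on the amide-type nitrogen, whereas this one shows that the phenyl ring of compound 3 is itself sensitive to change: in this assay, methoxy in place of hydrogen, para to a large group, gives an at least 10-fold higher number from compound 3 to compound 4 (1.01 log units; beyond the scatter). The value of compound 4 is a limit and not a number, so the steps linking it to compound 1 and compound 2 cannot be read. Compound 3 is now the only compound here with an actual number: the limit of > 100000 nM in this assay, at which 3 of the 4 values shown sit.

With only one substituent tried at this place, the compounds shown cannot tell whether the loss belongs to methoxy itself or would follow any group there. As far as these compounds go, whether a hydroxy, a chloro or an amine at that carbon would retain a measurable value in this assay also remains open.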